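The compounds below may be only part of what the source reports. "The series", "measured", "known", "first", "only" and "open" are said of these compounds alone.

Compound 2, `O=C(NCc1cnccn1)Nc1ccc(S(=O)(=O)c2ccccc2)cc1`, stands at the high end of the two numbers measured in an assay on isolated protein for inhibition of Nicotinamide phosphoribosyltransferase (Homo sapiens), read by spectrophotometry, with stated times of 15 min and 30 min; a higher number here means a weaker inhibitor, a lower number a stronger inhibitor: compound 2 gives 1300 nM, whereas compound 1, `O=C(NCc1ccc(Cl)nc1)Nc1ccc(S(=O)(=O)c2ccccc2)cc1`, gives 13 nM. Among the compounds with values here, the single step that connects them is a 100-fold higher number from compound 1 to compound 2 (2.00 log units; beyond the scatter), which shows that the aromatic group on the saturated chain carbon bound to the amide-type nitrogen governs the read-out strongly. Compound 3, `Nc1ncc(CNC(=O)Nc2ccc(S(=O)(=O)c3ccccc3)cc2)cn1`, changes exactly that group: 2-aminopyrimidin-5-yl in place of pyrazin-2-yl on a saturated chain carbon bound to an amide-type nitrogen. Because the step of a 100-fold higher number from compound 1 to compound 2 (2.00 log units; beyond the scatter) was large, a large step is also expected here, and since compound 2 sits at the weak extreme, the expectation is a move back toward the number of compound 1 rather than further away. Compound 3 is therefore estimated at 60 nM in this assay, within a range of 10 nM to 400 nM, meaning an expected step of a 22-fold lower number from compound 2 to compound 3 (1.34 log units; beyond the scatter).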

Compound 3, half-maximal inhibitory concentration: 14 nM
For compound 3 the middle estimate is 4.3-fold (0.63 log units) above the measured one, and the stated range covers the measured number.
By their numbers in this assay, from the lowest: compounds 1 and 3 (each within the scatter of the next); then compound 2.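

In this assay, the group on a saturated chain carbon bound to an amide-type nitrogen can move the read-out in both directions: a 93-fold lower number from compound 2 to compound 3 (1.97 log units; beyond the scatter), which offsets the loss seen in a 100-fold higher number from compound 1 to compound 2 (2.00 log units; beyond the scatter). With a 1.1-fold higher number from compound 1 to compound 3 (0.03 log units; within the scatter), 2-aminopyrimidin-5-yl and 6-chloropyridin-3-yl cannot be told apart here, so a chlorine on the ring is not required at this position, while pyrazin-2-yl stands apart from both. No available evidence bears on the reason for these differences.

The compounds shown leave open whether the gain belongs to the amine of 2-aminopyrimidin-5-yl or to its ring; the two change together in this step. A pyrimidin-5-yl group without the amine, or the same ring carrying a methoxy group, would separate them.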